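Adding an ethyl group to compound 1

This account rests on a few compounds, and the source may have more. Where it says the series, first, only, none or still open, it means among the compounds named here.

Compound 1 `CC[C@H](N)C(=O)N[C@@H]1C(=O)N2[C@@H](CC[C@@H]1CCN)CC[C@H]2C(=O)NC(c1ccccc1)c1ccccc1`: 25000 nM
Compound 2 `CC[C@H](NC)C(=O)N[C@@H]1C(=O)N2[C@@H](CC[C@@H]1CCNC(=O)NCc1ccccc1)CC[C@H]2C(=O)NC(c1ccccc1)c1ccccc1`: 52200 nM

For the measured compounds named here, in a functional assay on HL-60 cells (Homo sapiens) for cytotoxicity, read by MTT assay, with a stated time of 96 h (on this read-out lower numbers stand for stronger inhibition and higher numbers for weaker inhibition), compound 1 gives 25000 nM, the lower of the two numbers measured so far, and compound 2 gives 52200 nM. Compound 3 `CCNCC[C@H]1CC[C@H]2CC[C@@H](C(=O)NC(c3ccccc3)c3ccccc3)N2C(=O)[C@H]1NC(=O)[C@@H](N)CC` keeps the core of compound 1 and alters one place: ethyl in place of hydrogen on an amine nitrogen. Going by the values given here, no measured pair of compounds shows this change on its own, so the guidance is thin. In this assay no step beyond the scatter is expected, in either direction: the estimate is a 1.2-fold higher number from compound 1 to compound 3 (0.08 log units; within the scatter). The estimated value for compound 3 is 30000 nM, with an expected range of 11000 nM to 75000 nM.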

Compound 3, half-maximal inhibitory concentration: 62800 nM
For compound 3 the middle estimate is 2.1-fold (0.32 log units) below the measured one; low and high end bracket the measured number.
By their numbers in this assay, from the lowest: compound 1; then compounds 2 and 3 (each within the scatter of the next).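

In this assay, putting ethyl in place of hydrogen on this amine nitrogen, which turns 2-aminoethyl into 2-(ethylamino)ethyl, gives a 2.5-fold higher number from compound 1 to compound 3 (0.40 log units; beyond the scatter). For the compounds shown here, this is the first change at this position seen on its own, and it shows that even this small addition weakens inhibition, though only modestly. No measurement at hand explains the loss. Still open, on these data alone, is how methyl or a longer chain such as propyl on the same nitrogen would compare with ethyl. An acetamide in place of the amine is equally untested among the compounds shown.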